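The source may hold more compounds than are shown below. What is called first, only, known or untested is meant among the compounds shown, and "the series" means these compounds.

Measured so far:
- Compound 1, `CC1=NC(C)=C(C(=O)O)C(c2ccc([N+](=O)[O-])cc2)/C1=C(\O)OC/C=C/c1ccccc1`: 1600 nM
- Compound 2, `COC(=O)c1cccc(C2C(C(=O)O)=C(C)N=C(C)/C2=C(/O)OC/C=C/c2ccccc2)c1`: 4400 nM

The read-out throughout is a functional assay on thoracic aorta for inhibition of Voltage-gated L-type calcium channel (Rattus norvegicus); a higher number here means a weaker inhibitor, a lower number a stronger inhibitor. Within these two numbers compound 2 stands highest, with compound 1 as its only neighbour at a lower value. Among the measured compounds shown here, the single measured step between them, a 2.8-fold higher number from compound 1 to compound 2 (0.44 log units; beyond the scatter), is the only one that changes the aryl group on the saturated ring carbon of the shared core, and it is modest but beyond the scatter.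

The next compound, compound 3, `CC1=NC(C)=C(C(=O)O)C(c2cccc(Br)c2)/C1=C(\O)OC/C=C/c1ccccc1`, keeps the core and the cinnamyl ester of compound 2 and differs from it by bromo in place of methoxycarbonyl on an aromatic carbon. For the measured compounds named here, no measured step swaps one group for another on the same aromatic carbon, so the step from compound 1 to compound 2 is the only guide, and it shows only that changing the aryl portion moves this assay by a modest amount. The expectation is a step of similar size, most likely back towards the value of compound 1, but a value within the scatter of compound 2 cannot be excluded. This corresponds to an expected 2.9-fold lower number from compound 2 to compound 3 (0.47 log units; beyond the scatter). Compound 3 is therefore estimated at 1500 nM, with a range from 400 nM to 6000 nM.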

Compound 3, half-maximal inhibitory concentration: 10 nM
The estimate for compound 3 lay 150-fold (2.18 log units) above the measured number; measured number below the stated range.
By their numbers in this assay, from the lowest: compound 3; then compound 1; then compound 2.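

In this assay, among the compounds shown here, the aromatic carbon meta to a large group proves far more sensitive than the earlier pair suggested: bromo in place of methoxycarbonyl gives a 440-fold lower number from compound 2 to compound 3 (2.64 log units; beyond the scatter), whereas the only earlier step was a 2.8-fold higher number from compound 1 to compound 2 (0.44 log units; beyond the scatter). The exchange of 4-nitrophenyl for 3-bromophenyl on the saturated ring carbon gives a 160-fold lower number from compound 1 to compound 3 (2.20 log units; beyond the scatter), so among these three compounds the large change in the number goes with the 3-bromophenyl group, and the 4-nitrophenyl and 3-(methoxycarbonyl)phenyl groups both stand well away from it. Nothing in hand accounts for the size of these steps.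

The compounds shown leave open whether the low number is particular to bromo or would also appear with another group on the same aromatic carbon, such as chloro, methyl or nitrile. Since 4-nitrophenyl and 3-bromophenyl differ in both the group and its place on the aromatic ring, the contribution of each to the step from 4-nitrophenyl to 3-bromophenyl also remains unresolved.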